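Swapping trifluoromethyl for methyl at a low clearance limit

A few compounds are considered here, and "the series" means these few. Any claim that something is new, unique, unknown or untested is made for them only; others in the source may bear on it.

Compound 1 `CC(O)(c1ccc(-c2ccc(S(=O)(=O)c3ccc(N)nc3)cc2)cc1)C(F)(F)F` gives < 14 mL.min-1.g-1 (a limit)
Compound 2 `CC(O)(c1ccc(-c2ccc(S(=O)(=O)c3ccc(N)nc3)nc2NC2CCCCC2)nc1)C(F)(F)F` gives 280 mL.min-1.g-1 (a number)
Compound 3 `C[C@@](O)(c1ccc(-c2ncc(S(=O)(=O)c3ccc(N)nc3)s2)c(Cl)c1)C(F)(F)F` gives < 14 mL.min-1.g-1 (a limit)

These results come from an ADME assay (liver) for metabolic stability, with Liver microsome (Rattus norvegicus) as the target, using microsomes and NADPH, with a stated time of 30 min, at 37 degrees C, tested at 1 uM (a lower number here means slower removal, a higher number faster removal of the compound), and show how quickly liver microsomes remove each compound. In this assay compound 3 gives < 14 mL.min-1.g-1 as a limit and not a number. Compound 2 gives 280 mL.min-1.g-1 but differs from compound 3 in several places, so it says little about a single swap.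

Compound 4 `CC(C)(O)c1ccc(-c2ncc(S(=O)(=O)c3ccc(N)nc3)s2)c(Cl)c1` keeps the rest of compound 3 and changes one group. The change is 1-hydroxy-1-methylethyl in place of 1-hydroxy-1-(trifluoromethyl)ethyl on an aromatic carbon with 1-hydroxy-1-methylethyl in place of 1-hydroxy-1-(trifluoromethyl)ethyl on an aromatic carbon. Going by the values given here, no measured pair shows this swap alone, so the expectation is loose, and compound 4 may again return only a limit. The estimate is an at least 1.2-fold higher number from compound 3 to compound 4 (0.10 log units; that floor lies within the scatter) as an expected small rise, close to the usual scatter. Compound 4 is estimated at 18 mL.min-1.g-1 with a range from 9 mL.min-1.g-1 to 50 mL.min-1.g-1 in this assay as the working expectation.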

Compound 4, intrinsic clearance in microsomes: 17 mL.min-1.g-1
Compound 4: middle estimate off by 1.1-fold (0.02 log units), on the high side; the range from low to high includes it.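

Going by these compounds alone, this is the first pair of compounds that differ in only one place, and in this assay it gives an at least 1.2-fold higher number from compound 3 to compound 4 (0.08 log units; that floor lies within the scatter). So on this aromatic carbon, 1-hydroxy-1-methylethyl can replace 1-hydroxy-1-(trifluoromethyl)ethyl without a step that can be told from the scatter, although the same swap also removes the defined stereocentre. The true size of the step stays unknown because compound 3 gives a limit and not a number: the limit of < 14 mL.min-1.g-1 in this assay, at which 2 of the 4 values shown sit.

The compounds shown leave open how an amine or a carboxylic acid in place of the hydroxyl-bearing group would behave at this position. They also leave open whether the same swap would give a similar result on the core of compound 1, which carries the same 1-hydroxy-1-(trifluoromethyl)ethyl group.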